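A few compounds are considered here, and "the series" means these few. Any claim that something is new, unique, unknown or untested is made for them only; others in the source may bear on it.

Measured in a functional assay on DU-145 cells (Homo sapiens) for antiproliferative activity, read by sulforhodamine B assay, with a stated time of 72 h; on this read-out higher numbers stand for weaker inhibition and lower numbers for stronger inhibition
Compound 1 `O=S(=O)(Nc1ncccn1)c1ccc(Nc2nncc3ccccc23)cc1` gives 45 nM
Compound 2 `Fc1ccc(Nc2nncc3ccccc23)cc1` gives 4.3 nM
Compound 3 `O=S(=O)(Nc1ccccn1)c1ccc(Nc2nncc3ccccc23)cc1` gives 54 nM

Compound 3 (54 nM) sits level with compound 1 within the scatter, and both numbers lie well above that of compound 2. The next structure is compound 4 `NS(=O)(=O)c1ccc(Nc2nncc3ccccc23)cc1` and the change from compound 3 is hydrogen in place of pyridin-2-yl on a sulfonamide nitrogen. Among the compounds with values here, the one measured step at that nitrogen (a 1.2-fold higher number from compound 1 to compound 3 (0.08 log units; within the scatter)) swaps one ring for another, so no measurement shows what losing the ring does. Compound 2 (4.3 nM) carries no sulfonamide, yet its number is low. A small move toward lower numbers in this assay is therefore expected (a 1.8-fold lower number from compound 3 to compound 4 (0.26 log units; within the scatter)). The estimate for compound 4 is 30 nM (expected range 8 nM to 110 nM).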

Compound 4, half-maximal inhibitory concentration: 14 nM
Compound 4: middle estimate off by 2.1-fold (0.33 log units), on the high side; the range from low to high includes it.
By their numbers in this assay, from the lowest: compound 2; then compound 4; then compounds 1 and 3 (each within the scatter of the next).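

Taking the ring off the sulfonamide nitrogen does register in this assay: hydrogen in place of pyridin-2-yl brings a 3.9-fold lower number from compound 3 to compound 4 (0.59 log units; beyond the scatter) and hydrogen in place of pyrimidin-2-yl brings a 3.2-fold lower number from compound 1 to compound 4 (0.51 log units; beyond the scatter) although exchanging one ring for the other stayed within the scatter. The unsubstituted sulfonamide still does not reach the fluoro compound, since sulfamoyl in place of fluoro on an aromatic carbon brings a 3.3-fold higher number from compound 2 to compound 4 (0.51 log units; beyond the scatter) as the step. Going by these compounds, whether a methyl or acetyl group on that nitrogen would behave like hydrogen or like the rings stays open, as does how a carboxylic acid or an amine would compare in place of sulfamoyl. No measurement shown here explains any of these steps.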